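The compounds below may be only part of what the source reports. "The series", "measured", "known", "first", "only" and "open" are said of these compounds alone.

Measured in an in vitro ADME assay on microsomes from liver (Homo sapiens) for metabolic stability; a lower number here means that the compound disappears faster, a higher number that the compound lasts longer:
- compound 1 `COC[C@@H]1C[C@@H](C(=O)NC[C@H]2CCCO2)CN(Cc2nc(-c3ccccc3)oc2C)C1`: 0.07 h
- compound 2 `CC[C@@H]1C[C@@H](C(=O)NCc2cccc(N)n2)CN(Cc2nc(-c3ccccc3)oc2C)C1`: 0.0578 h
- compound 3 `COC[C@@H]1C[C@@H](C(=O)NCC2CCOCC2)CN(Cc2nc(-c3ccccc3)oc2C)C1`: 0.0682 h

The three values lie within the scatter of each other, so compound 1 stands level with the other two. Compound 4 `Cc1oc(-c2ccccc2)nc1CN1CCC[C@@H](C(=O)NC[C@H]2CCCO2)C1` has hydrogen in place of methoxymethyl on a saturated ring carbon.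

Among the compounds with values here, the only measured step, a 1.0-fold lower number from compound 1 to compound 3 (0.01 log units; within the scatter), changes the amide side chain rather than this carbon, so it bears on the change only indirectly. Within the data shown here, no measured step isolates the loss of methoxymethyl. With nothing pointing either way, no shift beyond the scatter is expected in this assay.

The estimated step is a 1.1-fold higher number from compound 1 to compound 4 (0.03 log units; within the scatter). Compound 4 is expected at 0.075 h, with an estimated range of 0.04 h to 0.15 h.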

Compound 4, half-life: 0.193 h
Compound 4: the middle estimate sits 2.6-fold (0.41 log units) below what was measured; measured number above the stated range.
By their numbers in this assay, from the lowest: compounds 2, 3 and 1 (each within the scatter of the next); then compound 4.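

In this assay hydrogen in place of methoxymethyl gives a 2.8-fold higher number from compound 1 to compound 4 (0.44 log units; beyond the scatter) and so shows that this saturated ring carbon can move the number beyond the scatter. The earlier step on the amide side chain, a 1.0-fold lower number from compound 1 to compound 3 (0.01 log units; within the scatter) and within the scatter, gave no such sign. No available evidence accounts for the rise.

Still open, on these data alone, is whether a methyl group, a hydroxyl group or a fluorine atom on this ring carbon would give a number like that of compound 4. Within the data shown here, also open is whether the step holds with other amide side chains, such as the one in compound 3.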